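This account rests on a few compounds, and the source may have more. Where it says the series, first, only, none or still open, it means among the compounds named here.

In a functional assay on HCT-116 cells (Homo sapiens) for inhibition, read by CCK-8 assay, with a stated time of 48 h (on this read-out lower numbers stand for stronger inhibition and higher numbers for weaker inhibition), compound 1 `COc1ccc(CN(C(=O)CSC(=S)N2CCN(C(=O)OC(C)(C)C)CC2)c2cc(OC)c(OC)c(OC)c2)cc1` gives 620 nM. With fluoro in place of hydrogen on an aromatic carbon, compound 2 `COc1ccc(CN(C(=O)CSC(=S)N2CCN(C(=O)OC(C)(C)C)CC2)c2cc(OC)c(OC)c(OC)c2)cc1F` gives 8210 nM. With bromo on that carbon, compound 3 `COc1ccc(CN(C(=O)CSC(=S)N2CCN(C(=O)OC(C)(C)C)CC2)c2cc(OC)c(OC)c(OC)c2)cc1Br` gives 9710 nM. Both are large steps: a 13-fold higher number from compound 1 to compound 2 (1.12 log units; beyond the scatter) and a 16-fold higher number from compound 1 to compound 3 (1.19 log units; beyond the scatter). Compound 3 therefore stands far from compound 1, yet the swap of bromo for fluoro is small: a 1.2-fold higher number from compound 2 to compound 3 (0.07 log units; within the scatter). Compound 4 `COc1ccc(CN(C(=O)CSC(=S)N2CCN(C(=O)OC(C)(C)C)CC2)c2cc(OC)c(OC)c(OC)c2)cc1[N+](=O)[O-]` carries nitro in place of bromo, ortho to a methoxy group: nitro in place of bromo on an aromatic carbon. Going by the values given here, only two groups have been measured on this carbon, but their closeness suggests no change beyond the scatter in this assay. The expected step is a 1.6-fold lower number from compound 3 to compound 4 (0.21 log units; within the scatter). For compound 4 the estimated value is 6000 nM, with an expected range from 1500 nM to 20000 nM.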

Compound 4, half-maximal inhibitory concentration: 980 nM
For compound 4 the middle estimate is 6.1-fold (0.79 log units) above the measured one; measured number below the stated range.
By their numbers in this assay, from the lowest: compounds 1 and 4 (each within the scatter of the next); then compounds 2 and 3 (each within the scatter of the next).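

Nitro on this carbon gives a 9.9-fold lower number from compound 3 to compound 4 (1.00 log units; beyond the scatter) and an 8.4-fold lower number from compound 2 to compound 4 (0.92 log units; beyond the scatter), so the closeness of fluoro and bromo does not hold for every group placed here. Compared with hydrogen, nitro gives a 1.6-fold higher number from compound 1 to compound 4 (0.20 log units; within the scatter), so a group on this carbon need not weaken inhibition in this assay. No available evidence explains why nitro behaves differently from the two halogens.

On these data alone, it remains open whether an amine, a nitrile or a carboxylic acid on this carbon would match nitro or the halogens.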